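The compounds below may be only part of what the source reports. "The series", "measured", "known", "first", "only" and "open" are said of these compounds alone.

Working notes on the series. Compound 1 `Cn1cnc(CN2CCN(c3cccc4[nH]c(-c5ccc(C(C)(C)C)cc5)nc34)CC2)c1` gives 33 nM in an assay on isolated protein for displacement of a labelled ligand from Gonadotropin-releasing hormone receptor (Homo sapiens); a lower number here means a stronger inhibitor, a higher number a weaker inhibitor; compound 2 `Cc1nc(CN2CCN(c3cccc4[nH]c(-c5ccc(C(C)(C)C)cc5)nc34)CC2)c[nH]1` gives 7.5 nM; compound 3 `CCCCn1cnc(CN2CCN(c3cccc4[nH]c(-c5ccc(C(C)(C)C)cc5)nc34)CC2)c1C` gives 46 nM and so sits at the highest number of the three, with a 1.4-fold higher number from compound 1 to compound 3 (0.14 log units; within the scatter) and a 6.1-fold higher number from compound 2 to compound 3 (0.79 log units; beyond the scatter). The next step to compound 4 `CCn1cc(CN2CCN(c3cccc4[nH]c(-c5ccc(C(C)(C)C)cc5)nc34)CC2)nc1C` is 1-ethyl-2-methyl-1H-imidazol-4-yl in place of 1-butyl-5-methyl-1H-imidazol-4-yl on a saturated chain carbon bound to an amine nitrogen in a ring. Among the measured compounds shown here, two measured steps bear on it: a 1.4-fold higher number from compound 1 to compound 3 (0.14 log units; within the scatter) shows that the butyl and 5-methyl substitution changed little, while a 4.4-fold lower number from compound 1 to compound 2 (0.64 log units; beyond the scatter) and a 6.1-fold higher number from compound 2 to compound 3 (0.79 log units; beyond the scatter) show that the 2-methyl-1H-imidazol-4-yl arrangement carried the lowest number. Compound 4 keeps an alkyl on the ring nitrogen yet carries the 2-methyl; a modest lowering beyond the scatter is therefore expected, estimated as a 2.3-fold lower number from compound 3 to compound 4 (0.36 log units; beyond the scatter). For compound 4 the expected value is 20 nM, within 7 nM to 55 nM.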

Compound 4, half-maximal inhibitory concentration: 10 nM
Estimate against measurement, compound 4: 2.0-fold (0.30 log units) above, and the stated range covers the measured number.
By their numbers in this assay, from the lowest: compounds 2 and 4 (each within the scatter of the next); then compounds 1 and 3 (each within the scatter of the next).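

In this assay ethyl in place of hydrogen on an aromatic nitrogen leaves the number within the scatter, with a 1.3-fold higher number from compound 2 to compound 4 (0.12 log units; within the scatter) as the step, so the 2-methyl-1H-imidazol-4-yl arrangement keeps its low number with an alkyl on that nitrogen. Compound 4 also separates from both other alkylated compounds, with a 4.6-fold lower number from compound 3 to compound 4 (0.66 log units; beyond the scatter) and a 3.3-fold lower number from compound 1 to compound 4 (0.52 log units; beyond the scatter) as the steps. No measurement on hand accounts for this difference.

The step from compound 3 changes the chain and the methyl together, and the two contributions stay unseparated. On these data alone, how far the ring nitrogen tolerates a chain ending in an amine or a carboxylic acid also remains open.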